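Swapping 2,5-dimethoxyphenyl for 3-chlorophenyl in the series

A few compounds are considered here, and "the series" means these few. Any claim that something is new, unique, unknown or untested is made for them only; others in the source may bear on it.

Of the compounds shown here, three have been measured in a functional assay on MCF7 cells (Homo sapiens) for cytotoxicity, read by MTT assay, with a stated time of 48 h; a lower number here means a stronger inhibitor, a higher number a weaker inhibitor. Compound 1 `O=C1/C(=C\c2ccc([N+](=O)[O-])cc2)S/C(=N/c2ccccc2)N1Cc1ccncc1` gives 13000 nM, compound 2 `O=C1/C(=C\c2ccc(O)c(O)c2)S/C(=N/c2ccccc2)N1Cc1ccncc1` gives 12400 nM, and compound 3 `COc1ccc(OC)c(/C=C2/S/C(=N/c3ccccc3)N(Cc3ccncc3)C2=O)c1` gives 37000 nM, the highest of the three numbers.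

Compound 4 `O=C1/C(=C\c2cccc(Cl)c2)S/C(=N/c2ccccc2)N1Cc1ccncc1` carries 3-chlorophenyl in place of 2,5-dimethoxyphenyl on a double-bonded chain carbon bound to a double-bonded ring carbon.

For the measured compounds named here, all the measured steps change this same place. Two of them lead to the 2,5-dimethoxyphenyl group: a 2.8-fold higher number from compound 1 to compound 3 (0.45 log units; beyond the scatter) and a 3.0-fold higher number from compound 2 to compound 3 (0.47 log units; beyond the scatter). Both are modest. The third, a 1.0-fold lower number from compound 1 to compound 2 (0.02 log units; within the scatter), does not separate 4-nitrophenyl from 3,4-dihydroxyphenyl. Among three compounds, then, only compound 3 stands apart, and two quite different groups give matching numbers. Going by the values given here, none of the measured compounds carries 3-chlorophenyl, so this is a thin basis for a forecast. Compound 4 is expected to move back toward compound 1, with its 13000 nM, without passing far beyond it. The expected change is a 2.3-fold lower number from compound 3 to compound 4 (0.36 log units; beyond the scatter), a modest step toward a lower number in this assay. For compound 4 the estimated value is 16000 nM, with an expected range of 6000 nM to 40000 nM.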

Compound 4, half-maximal inhibitory concentration: 29800 nM
The estimate for compound 4 lay 1.9-fold (0.27 log units) below the measured number; low and high end bracket the measured number.
By their numbers in this assay, from the lowest: compounds 2 and 1 (each within the scatter of the next); then compounds 4 and 3 (each within the scatter of the next).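

In this assay, 3-chlorophenyl and 2,5-dimethoxyphenyl are not separated at this place on a double-bonded chain carbon bound to a double-bonded ring carbon (a 1.2-fold lower number from compound 3 to compound 4 (0.09 log units; within the scatter)), so compound 3 no longer stands apart on its own. The series now falls into two pairs, with compound 4 sitting apart from the 3,4-dihydroxyphenyl and 4-nitrophenyl compounds (a 2.4-fold higher number from compound 2 to compound 4 (0.38 log units; beyond the scatter); a 2.3-fold higher number from compound 1 to compound 4 (0.36 log units; beyond the scatter)), and both steps are modest. The pair of compound 3 and compound 4 joins two groups that differ in heavy atoms and in hydrogen-bond acceptors, yet no measurement at hand accounts for how the four groups divide.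

The compounds shown leave open whether an amine or a carboxylic acid on this aromatic ring would join either pair or give a number outside both. On these data alone, all four compounds differ only at this one place, so the response of the series to changes elsewhere on the shared core also remains open.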